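A Tertiary Alcohol in Place of a Small Carbon Cage

This account rests on a few compounds, and the source may have more. Where it says the series, first, only, none or still open, it means among the compounds named here.

Measured so far:
Compound 1 `CC(C)S(=O)(=O)Nc1ccc(CNC(=O)c2ccc(C(C)(C)C)cc2)c(Cl)c1` gives 23 mL.min-1.g-1 in an ADME assay on microsomes from liver (Rattus norvegicus, strain Sprague-Dawley) for metabolic stability, read by HPLC, using NADPH, with stated times of 5 min and 60 min, tested at 10 uM; a lower number here means slower removal, a higher number faster removal of the compound.
Compound 2 `CS(=O)(=O)Nc1ccc(CNC(=O)c2ccc(C34CC(C3)C4)cc2)c(Cl)c1` gives 17 mL.min-1.g-1 in this assay.

Both compounds share the same core and were followed in this assay. The two numbers sit within the usual scatter of each other, so compound 2 cannot be set apart from compound 1 on this reading; the two are best taken as alike.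

Compound 3 `CC(C)(O)c1ccc(C(=O)NCc2ccc(NS(C)(=O)=O)cc2Cl)cc1` is the next compound, not yet measured. It differs from compound 2 in a single place: a group of 4 heavy atoms (3 carbon, 1 oxygen; no ring) in place of a group of 5 heavy atoms (5 carbon; 2 four-membered non-aromatic rings of carbon only), on an aromatic carbon. Among the measured compounds shown here, no measured pair in this set shows a step of this kind, so the expectation rests on compound 2 alone.

For compound 3 the expected step is a 1.4-fold lower number from compound 2 to compound 3 (0.15 log units; within the scatter), a small move that would most likely stay within the scatter. Compound 3 is therefore estimated at 12 mL.min-1.g-1, with a range from 5 mL.min-1.g-1 to 30 mL.min-1.g-1.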

Compound 3, intrinsic clearance in microsomes: 1.5 mL.min-1.g-1
Estimate against measurement, compound 3: 8.0-fold (0.90 log units) above; measured number outside the range, below it.
By their numbers in this assay, from the lowest: compound 3; then compounds 2 and 1 (each within the scatter of the next).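

At this position, on an aromatic carbon para to a large group, the choice of group can strongly change the result in this assay: replacing the group with two four-membered carbon rings by 1-hydroxy-1-methylethyl gives an 11-fold lower number from compound 2 to compound 3 (1.05 log units; beyond the scatter). Among the compounds shown here, compound 1 and compound 2 differ in more than one place, so only this pair isolates a change at this position. Nothing measured here tells why the number moved so far.

A single change also replaces the rings and adds the oxygen together, so it cannot show which of these matters. Placing an amine, such as 1-amino-1-methylethyl, or a longer chain ending in a hydroxyl group at this position would test how specific the step is to 1-hydroxy-1-methylethyl.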